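Replacing Butyl with 4-Methoxyphenyl on the Aromatic Nitrogen

The source may hold more compounds than are shown below. What is called first, only, known or untested is meant among the compounds shown, and "the series" means these compounds.

Measured compounds:
compound 1 `CCCCn1ccnc1-c1cc(OC)c(OC)c(OC)c1`: > 100000 nM
compound 2 `COc1cc(OC)cc(-n2ccnc2-c2cc(OC)c(OC)c(OC)c2)c1`: 74500 nM
compound 3 `COc1cc(-c2nccn2-c2cccc([N+](=O)[O-])c2)cc(OC)c1OC`: > 100000 nM

Compound 1 sits at the limit of > 100000 nM in this assay, at which 2 of the 3 values shown sit. In a functional assay on HT-29 cells (Homo sapiens) for antiproliferative activity, read by MTT assay, with a stated time of 72 h (on this read-out higher numbers stand for weaker inhibition and lower numbers for stronger inhibition), compound 1 therefore gives only a limit, > 100000 nM, and no number. For the measured compounds named here, compound 2 is the one compound with a number in this assay, 74500 nM, and that number stands for weak inhibition. Compound 4 `COc1ccc(-n2ccnc2-c2cc(OC)c(OC)c(OC)c2)cc1` differs from compound 1 in one place: 4-methoxyphenyl in place of butyl on an aromatic nitrogen. No measured step connects two of these compounds, so the expected step is a guess from the neighbours. Compound 4 is expected to stay weak, with a step of an at least 1.1-fold lower number from compound 1 to compound 4 (0.04 log units; that floor lies within the scatter) that is not beyond the scatter, because compound 2, which also carries a methoxy-bearing ring on the aromatic nitrogen, gives 74500 nM. The estimate for compound 4 is 90000 nM, in the range 30000 nM to 300000 nM.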

Compound 4, half-maximal inhibitory concentration: 13100 nM
For compound 4 the middle estimate is 6.9-fold (0.84 log units) above the measured one, and the stated range ends above it.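

In this assay, the group on the aromatic nitrogen proves to matter: 4-methoxyphenyl in place of butyl gives an at least 7.6-fold lower number from compound 1 to compound 4 (0.88 log units; beyond the scatter). That step is only a floor, since compound 1 gives a limit and no number: the limit of > 100000 nM in this assay, at which 2 of the 4 values shown sit. Compound 3 also carries a six-membered aromatic ring on this nitrogen and gives only a limit, > 100000 nM, so such a ring alone does not bring the lower number.

Still open, going by these compounds, is how a hydroxyl or an amine in place of the methoxy would read. Also open, on these data alone, is whether a benzyl group on this nitrogen would behave like butyl or like 4-methoxyphenyl.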